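Halogen swap on the anilino ring of compound 1

The compounds below may be only part of what the source reports. "The series", "measured", "known", "first", "only" and "open" are said of these compounds alone.

Compound 1 `CCn1c(=O)/c(=C2\Sc3ccccc3N2C)s/c1=C\c1ccncc1Nc1ccccc1F` and compound 2 `c1ccc(Nc2nc(-c3nc4ccccc4s3)cs2)cc1` have been measured in a functional assay on CWR22R cells (Homo sapiens) for inhibition; a lower number here means a stronger inhibitor, a higher number a weaker inhibitor. Compound 1 gives 300 nM, the lowest of the two numbers; compound 2 gives 6900 nM, a gap well beyond the usual scatter. Compound 3 `CCn1c(=O)/c(=C2\Sc3ccccc3N2C)s/c1=C\c1ccncc1Nc1ccccc1Cl` has not yet been measured. It differs from compound 1 in one place: chloro in place of fluoro on an aromatic carbon. Going by the values given here, no pair of measured compounds shows the effect of this change, and compound 2 shares neither the core of compound 1 nor the (2-fluorophenyl)amino group, so it offers no guide to the size of the step. With nothing measured to point either way, the expected step of a 1.2-fold lower number from compound 1 to compound 3 (0.08 log units; within the scatter) is none beyond the scatter, in either direction. For compound 3 the estimated value in this assay is therefore 250 nM, with a range from 110 nM to 600 nM.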

Compound 3, half-maximal inhibitory concentration: 460 nM
The estimate for compound 3 lay 1.8-fold (0.26 log units) below the measured number; the range from low to high includes it.
By their numbers in this assay, from the lowest: compounds 1 and 3 (each within the scatter of the next); then compound 2.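

In this assay, the change from (2-fluorophenyl)amino to (2-chlorophenyl)amino gives a 1.5-fold higher number from compound 1 to compound 3 (0.19 log units; within the scatter), so at this position, on the aromatic ring and ortho to a large group, the two halogens cannot be told apart. This pair is the only one-place step among the compounds shown, and it indicates that the number seen for compound 1 does not depend on fluoro in particular. Nothing measured here speaks to the reason for this result. 

Still open, on these data alone, is whether a group other than a halogen at this position, such as methoxy, an amine or a carboxylic acid, would move the number beyond the scatter. The compounds shown also leave open how compound 1 would read with plain phenyl in place of 2-fluorophenyl.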